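A few compounds are considered here, and "the series" means these few. Any claim that something is new, unique, unknown or untested is made for them only; others in the source may bear on it.

Going by the values given here, compound 1 `COC(=O)c1c(Nc2ccccc2)sc(C(=O)c2ccc(OC)cc2)c1C` is one of two compounds measured so far in a functional assay, with a stated time of 150 min, tested at 20 ug/mL; on this read-out lower numbers stand for a weaker effect and higher numbers for a stronger effect at the one concentration tested. In that assay compound 1 gives 32.4%, the higher of the two numbers. Its neighbour, compound 2 `COC(=O)c1c(Nc2ccc(OC)cc2)sc(C(=O)c2ccc(OC)cc2)c1C`, carries a methoxy in place of hydrogen on an aromatic carbon, and compound 2 gives 12%. That single measured step, a number 20.4 percentage points lower from compound 1 to compound 2 (beyond the scatter), is the only one available, and it concerns a different part of the molecule.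

The compound now in question is compound 3 `COc1ccc(C(=O)c2sc(Nc3ccccc3)c(C(=O)O)c2C)cc1`. Compared with compound 1, the change is hydrogen in place of methyl on an oxygen next to a carbonyl group, so the methoxycarbonyl of compound 1 becomes a carboxy in compound 3. Among the compounds with values here, no measured step touches that oxygen, so the one step on record says nothing about this change, and the expectation for compound 3 must rest mainly on the value of compound 1 itself.

On that basis compound 3 is expected to give 25%, within a range from 5% to 50%. This estimate means a step of a number 7.4 percentage points lower from compound 1 to compound 3 (within the scatter), which is expected to stay within or close to the usual scatter.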

Compound 3, a percentage reported as activity, at one concentration (the size of the read-out at that concentration, not a potency): 41.2%
Compound 3: middle estimate off by 16.2 percentage points, on the low side, and the stated range covers the measured number.
By their numbers in this assay, from the lowest: compound 2; then compounds 1 and 3 (each within the scatter of the next).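

In this assay, swapping methoxycarbonyl for carboxy gives a number 8.8 percentage points higher from compound 1 to compound 3 (within the scatter), so on this read-out the two compounds cannot be told apart. Going by these compounds alone, this is the first sign that the methyl on this oxygen can be replaced by hydrogen without a shift beyond the scatter at the one concentration tested, unlike the methoxy change elsewhere in the molecule, which gave a number 20.4 percentage points lower from compound 1 to compound 2 (beyond the scatter). Nothing available explains why this exchange leaves the number within the scatter.

The compounds shown leave open how an amide or an ethyl ester would read at this place, since only the methyl ester and the free carboxy acid are compared here. They also leave open whether the same exchange would behave alike on compound 2, which carries the extra methoxy, and whether a result from a single pair at one concentration would hold across a wider set of compounds.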